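Two Bromoindole Compounds and an Untested Naphthalen-2-yl Analogue

This account rests on a few compounds, and the source may have more. Where it says the series, first, only, none or still open, it means among the compounds named here.

Measured in a functional assay on MCF7 cells (Homo sapiens) for inhibition, read by MTT assay, with a stated time of 48 h; a higher number here means a weaker inhibitor, a lower number a stronger inhibitor:
- Compound 1 `COc1cccc(C(c2c[nH]c3ccc(Br)cc23)c2c[nH]c3ccc(Br)cc23)c1OC`: 89000 nM
- Compound 2 `COc1ccc(C(c2c[nH]c3ccc(Br)cc23)c2c[nH]c3ccc(Br)cc23)cc1OC`: 7800 nM

Of these two, compound 2 has the lower number, so it is the stronger inhibitor. Compound 3 `Brc1ccc2[nH]cc(C(c3ccc4ccccc4c3)c3c[nH]c4ccc(Br)cc34)c2c1` carries naphthalen-2-yl in place of 3,4-dimethoxyphenyl on a saturated chain carbon bound to two aromatic carbons. Within the data shown here, one measured step bears on this place, an 11-fold lower number from compound 1 to compound 2 (1.06 log units; beyond the scatter), and it was large. Among the measured compounds shown here, it shows that this place can matter, but no measured step introduces naphthalen-2-yl, so the direction remains uncertain. A small change towards a higher number is expected, estimated as a 1.4-fold higher number from compound 2 to compound 3 (0.15 log units; within the scatter). In this assay, compound 3 is expected to give 11000 nM, within an estimated range of 3500 nM to 35000 nM.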

Compound 3, half-maximal inhibitory concentration: 7100 nM
For compound 3 the middle estimate is 1.5-fold (0.19 log units) above the measured one; the range from low to high includes it.
By their numbers in this assay, from the lowest: compounds 3 and 2 (each within the scatter of the next); then compound 1.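

In this assay, naphthalen-2-yl, with no hydrogen-bond acceptors, replaces 3,4-dimethoxyphenyl, with two, and the result is a 1.1-fold lower number from compound 2 to compound 3 (0.04 log units; within the scatter) on a saturated chain carbon bound to two aromatic carbons. This place therefore tolerates a second aromatic ring in place of the two methoxy groups, while a 13-fold lower number from compound 1 to compound 3 (1.10 log units; beyond the scatter) leaves 2,3-dimethoxyphenyl apart from both other groups. No measurement shown here explains these numbers.

The compounds shown leave open how unsubstituted phenyl would read at this place. They also leave open whether an amine or a carboxylic acid on that ring would change the number.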